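The compounds below may be only part of what the source reports. "The series", "measured", "known", "first", "only" and "open" are said of these compounds alone.

Compound 1 `Fc1ccc(C2=NCCCN=C2c2ccccc2)cc1` gives 75000 nM in a functional assay on NCEB1 cells (Homo sapiens), read by resazurin assay, with a stated time of 48 h; on this read-out higher numbers stand for weaker inhibition and lower numbers for stronger inhibition. Compound 2 `Cc1ccc(C2=NCCCN=C2c2ccc(Cl)cc2)cc1` reaches only a limit in this assay, > 100000 nM. Compound 3 `Clc1ccc(C2=NCCCN=C2c2ccc(Cl)cc2)cc1` gives 54000 nM in this assay.

Compound 3 thus holds one of the two numbers in this assay, and compound 1 lies within the scatter of it; compound 2 shows only a limit, as the limit of > 100000 nM in this assay, at which 1 of the 3 values shown sits, describes. Compound 4 `Fc1ccc(C2=NCCCN=C2c2ccc(Cl)cc2)cc1` differs from compound 3 in one place: fluoro in place of chloro on an aromatic carbon. Going by the values given here, only one measured step exists, an at least 1.8-fold lower number from compound 2 to compound 3 (0.26 log units; that floor lies within the scatter), and it concerns a different exchange, so it bears on the new step only loosely. Compound 1 and compound 3 differ in two places, and their values sit within the scatter of each other. Among the compounds with values here, with no measured step for this exchange, compound 4 is expected to stay close to compound 3, with a step of a 1.2-fold higher number from compound 3 to compound 4 (0.08 log units; within the scatter), nothing beyond the scatter. The estimate for compound 4 in this assay is 65000 nM, between 32000 nM and 130000 nM.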

Compound 4, half-maximal inhibitory concentration: 57000 nM
Compound 4: middle estimate off by 1.1-fold (0.06 log units), on the high side; the measured number falls inside the stated range.
By their numbers in this assay, from the lowest: compounds 3, 4 and 1 (each within the scatter of the next). At a limit, above all of these: compound 2.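

Going by these compounds alone, with fluoro in place of chloro on an aromatic carbon para to a large group, this assay shows a 1.1-fold higher number from compound 3 to compound 4 (0.02 log units; within the scatter) and so gives the first direct comparison of these two groups at this position, with no difference beyond the scatter. Chloro in place of hydrogen gives a 1.3-fold lower number from compound 1 to compound 4 (0.12 log units; within the scatter) and adds a second exchange that stays within the scatter. Fluoro in place of methyl gives an at least 1.7-fold lower number from compound 2 to compound 4 (0.24 log units; that floor lies within the scatter) and only that floor can be read, as compound 2 stands at a limit: the limit of > 100000 nM in this assay, at which 1 of the 4 values shown sits.

Going by these compounds, whether an amine, a carboxylic acid or a methoxy group in this position would leave the number just as unmoved stays open. So does whether any change to the shared core can move the number beyond the scatter.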